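A few compounds are considered here, and "the series" means these few. Any claim that something is new, unique, unknown or untested is made for them only; others in the source may bear on it.

Measured in an ADME assay on L929 cells (Mus musculus) for cytotoxicity, read by resazurin assay, with a stated time of 48 h; on this read-out higher numbers stand for lower toxicity in this test and lower numbers for higher toxicity in this test:
- compound 1 `COC(=O)Cn1c2ccc([N+](=O)[O-])cc2c(=O)n1Cc1ccccc1`: 129000 nM
- compound 2 `COC(=O)CCn1c2ccc([N+](=O)[O-])cc2c(=O)n1Cc1ccccc1`: > 256000 nM (a limit)
- compound 3 `CC(=O)OCCn1c2ccc([N+](=O)[O-])cc2c(=O)n1Cc1ccccc1`: > 256000 nM (a limit)

Compound 3 is known only as a limit, sitting at the limit of > 256000 nM in this assay, at which 2 of the 3 values shown sit.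

Compound 4 `CC(=O)n1c2ccc([N+](=O)[O-])cc2c(=O)n1Cc1ccccc1` carries acetyl in place of 2-acetoxyethyl on an aromatic nitrogen.

Two measured steps change the group on that nitrogen: an at least 1.9-fold higher number from compound 1 to compound 2 (0.29 log units; that floor lies within the scatter) and an at least 1.9-fold higher number from compound 1 to compound 3 (0.29 log units; that floor lies within the scatter). Both floors lie within the scatter, and a step that the two limits leave unreadable from compound 2 to compound 3 adds nothing.

For the measured compounds named here, the only true number is that of compound 1 at 129000 nM, so a modest drop is expected. The expected change is an at least 1.7-fold lower number from compound 3 to compound 4 (0.23 log units; that floor lies within the scatter), towards lower numbers and not clearly beyond the scatter.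

Compound 4 is estimated at 150000 nM, with a range from 60000 nM to 256000 nM, in this assay.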

Compound 4, concentration lethal to 50% of the cells: > 256000 nM
Compound 4 gave a limit, no number; the forecaster's own chance of this, stated with the estimate: 30%; middle value at least 1.7-fold (0.23 log units) from the limit.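

In this assay, compound 4 is also known only as a limit, so acetyl on the aromatic nitrogen, with 3 heavy atoms in place of the 6 of 2-acetoxyethyl, gives no true number either: the limit of > 256000 nM in this assay, at which 3 of the 4 values shown sit.

For the compounds shown here, the only readable new step is an at least 1.9-fold higher number from compound 1 to compound 4 (0.29 log units; that floor lies within the scatter); the steps joining compound 4 to compound 2 and compound 3 cannot be read. Going by these compounds alone, compound 1 remains the only compound here with a true number, 129000 nM.

On these data alone, how a carboxylic acid or an amine at the end of the chain on this nitrogen would read in this assay stays open.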